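The compounds below may be only part of what the source reports. "The series", "measured", "known", "first", "only" and "open" are said of these compounds alone.

Working notes on the series.

Two compounds of the shared core carry a measured number in an assay on HEK293 cells for displacement of a labelled ligand from 5-hydroxytryptamine receptor 6 (Homo sapiens); on this read-out lower numbers stand for stronger inhibition and higher numbers for weaker inhibition. Compound 1, `O=C1c2ccccc2S(=O)(=O)N1CCCCCN1CCN(c2cccc(Cl)c2Cl)CC1`, gives 197 nM in this assay. Compound 2, `O=C1c2ccccc2S(=O)(=O)N1CCCCCCN1CCN(c2ccc(Cl)cc2)CC1`, gives 72 nM in this assay. Of the two numbers, compound 1 stands highest; compound 2 has the lower number, and the gap between them is beyond the scatter. No single-point change between measured compounds is available, so nothing measured yet tells how the aryl group on the ring nitrogen moves the number.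

Compound 3, `O=C1c2ccccc2S(=O)(=O)N1CCCCCN1CCN(c2ccccn2)CC1`, has not been measured in this assay. It differs from compound 1 in one place: pyridin-2-yl in place of 2,3-dichlorophenyl on an amine nitrogen in a ring. Among the measured compounds shown here, no measured pair shows this change, so the expectation rests on compound 1 alone and on the plain fact that its number is the higher of the two known. A modest rise in the number is expected from compound 1 to compound 3, a 2.0-fold higher number from compound 1 to compound 3 (0.31 log units; beyond the scatter), with real uncertainty in both directions. For compound 3 the estimate in this assay is 400 nM, with a range from 120 nM to 1300 nM.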

Compound 3, inhibition constant: 2630 nM
The estimate for compound 3 lay 6.6-fold (0.82 log units) below the measured number, and the stated range ends below it.
By their numbers in this assay, from the lowest: compound 2; then compound 1; then compound 3.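

In this assay, among the compounds shown here, the first single-point step at this position, on an amine nitrogen in the six-membered ring, is large: pyridin-2-yl in place of 2,3-dichlorophenyl gives a 13-fold higher number from compound 1 to compound 3 (1.13 log units; beyond the scatter). The number is therefore sensitive to the aryl group at this site, a point that compounds 1 and 2 could not establish, as they differ in more than one place. The step combines the loss of both chlorine atoms with the entry of a ring nitrogen and a hydrogen-bond acceptor, and nothing available accounts for its size.

Which of these differences carries the step remains open. A plain phenyl group on the same core would separate the loss of the chlorine atoms from the entry of the ring nitrogen, and a pyrimidin-2-yl group would test a further ring nitrogen.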